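Methyl on the Phenol Oxygen: Compound 1 to Compound 3

The source may hold more compounds than are shown below. What is called first, only, known or untested is meant among the compounds shown, and "the series" means these compounds.

In a functional assay on SK-MEL-5 cells (Homo sapiens) for inhibition, read by sulforhodamine B assay, with a stated time of 48 h, tested at 0.1 uM (a lower number here means a stronger effect, a higher number a weaker effect of the compound at the concentration tested), compound 1 `O=C(Nc1cccc(-n2cc(-c3ccncc3)c(-c3cc(O)cc(Cl)c3)n2)c1)Nc1ccc(Cl)c(Cl)c1` gives 92%, the lowest of the two numbers measured. Compound 2 `COc1cc(Cl)cc(-c2nn(-c3cccc(NC(=O)Nc4cc(C(F)(F)F)cc(C(F)(F)F)c4)c3)cc2-c2ccncc2)c1` gives 97%, and the two values lie within the scatter of each other, so neither can be called the stronger. Compound 3 `COc1cc(Cl)cc(-c2nn(-c3cccc(NC(=O)Nc4ccc(Cl)c(Cl)c4)c3)cc2-c2ccncc2)c1` has not been measured. It differs from compound 1 in one place: methyl in place of hydrogen on an oxygen on an aromatic ring. Among the measured compounds shown here, with no step of this kind among the measured compounds, the expected step is a number 2 percentage points higher from compound 1 to compound 3 (within the scatter), none beyond the scatter. Compound 3 is therefore estimated at 94%, in the range 84% to 100%.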

Compound 3, a percentage reported as activity, at one concentration (the size of the read-out at that concentration, not a potency): 96%
For compound 3 the middle estimate is 2 percentage points below the measured one; low and high end bracket the measured number.
By their numbers in this assay, from the lowest: compounds 1, 3 and 2 (each within the scatter of the next).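

In this assay, among the compounds shown here, the change from hydroxy to methoxy gives a number 4 percentage points higher from compound 1 to compound 3 (within the scatter) and so is the first single change read at this oxygen. Methyl can therefore take the place of hydrogen here without a difference that stands clear of the scatter. Nothing measured gives a reason for this result. Still open, as far as these compounds go, is how a longer chain on this oxygen, such as ethyl, would read. Also open, from the compounds shown here alone, is how an amine in place of the hydroxy would read on the same 3-chloro-5-substituted phenyl ring.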